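Adding a chloro to the benzyl ring of a shared core

The source may hold more compounds than are shown below. What is called first, only, known or untested is meant among the compounds shown, and "the series" means these compounds.

Compound 3 `COc1ccc(C2N=C(SCc3ccccc3)NC(C)=C2C(=O)Nc2ccc(Br)cc2)cc1` gives 2.6% in a functional assay on the whole organism (artery, strain albino) with Rattus norvegicus as the target, with a stated time of 30 min, at a dose of 10 mg/kg by the oral route; a higher number here means more inhibition at the dose given (going by the name of the read-out), a lower number less inhibition. This is the lowest of the three numbers measured, but compound 1 `CC1=C(C(=O)Nc2ccc(F)cc2)C(c2ccc([N+](=O)[O-])cc2)N=C(SCc2ccccc2Cl)N1` gives 3.1% and compound 2 `CC1=C(C(=O)Nc2ccc(Br)cc2)C(c2ccc(Cl)cc2Cl)N=C(SCc2ccccc2)N1` gives 3.6%, both within the scatter of compound 3. Going by the values given here, the one measured step, a number 1 percentage points lower from compound 2 to compound 3 (within the scatter), changed a different part of the molecule and stayed within the scatter. Compound 4 `COc1ccc(C2N=C(SCc3cccc(Cl)c3)NC(C)=C2C(=O)Nc2ccc(Br)cc2)cc1` carries chloro in place of hydrogen on an aromatic carbon, placed on the six-membered aromatic ring of carbon only, meta to a large group. Among the compounds with values here, no measured step bears on a chloro at that ring, so the expectation rests on all three values lying close together and on a number 1 percentage points lower from compound 2 to compound 3 (within the scatter) being flat. Compound 4 is therefore expected to give about 4%, between 0% and 12%, a step of a number 1.4 percentage points higher from compound 3 to compound 4 (within the scatter) that is not expected to exceed the scatter.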

Compound 4, a percentage reported as inhibition, in the whole organism at one dose (the size of the read-out at that dose, not a potency): 7.7%
Estimate against measurement, compound 4: 3.7 percentage points below; the measured number falls inside the stated range.
By their numbers in this assay, from the lowest: compounds 3, 1, 2 and 4 (each within the scatter of the next).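

Turning benzyl into 3-chlorobenzyl on the shared core gives a number 5.1 percentage points higher from compound 3 to compound 4 (within the scatter) in this assay, the first step read directly at this ring. Because that step stays within the scatter, this single chloro cannot be said to change inhibition at this dose. No supporting measurement offers an explanation for the step. Still open, as far as these compounds go, is whether a larger or different group on this ring, such as an amine or a carboxylic acid, would move the number beyond the scatter. Also open, from the compounds shown here alone, is whether a chloro elsewhere on this ring would read the same.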